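Swapping Phenyl for Cyclohexyl on the Imine Nitrogen

The source may report more compounds than this note shows. Statements on the series, on what has been measured and on what is new or still open speak of the compounds shown alone.

Compound 2 `CC(C)C1CC(=O)c2s/c(=N/c3ccccc3)oc2C1` gives 1150 nM in a functional assay on HCT-15 cells (Homo sapiens) for antiproliferative activity, read by sulforhodamine B assay (on this read-out lower numbers stand for stronger inhibition of growth and higher numbers for weaker inhibition of growth), the lowest of the three numbers at hand. Compound 1 `CC1CC(=O)c2s/c(=N/c3ccccc3)oc2C1` gives 2070 nM, and the step of a 1.8-fold lower number from compound 1 to compound 2 (0.26 log units; within the scatter) lies within the scatter. Compound 3 `CC1(C)CC(=O)c2s/c(=N/C3CCCCC3)oc2C1` gives 12200 nM, a number well beyond the scatter above compound 2.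

Compound 4 `CC(C)C1CC(=O)c2s/c(=N/C3CCCCC3)oc2C1` differs from compound 2 by cyclohexyl in place of phenyl on a double-bonded nitrogen. Within the data shown here, no measured step shows exactly this change on an otherwise matching core. Among the measured compounds shown here, the only cyclohexyl-bearing compound, compound 3, shows the weakest growth inhibition of the set, though it also carries a different substituent on the saturated ring, so its value can only hint. Compound 4 is therefore expected to give a higher number, roughly a 5.2-fold higher number from compound 2 to compound 4 (0.72 log units; beyond the scatter), estimated at 6000 nM with a range from 2000 nM to 18000 nM.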

Compound 4, concentration for 50% growth inhibition: 3530 nM
Compound 4: middle estimate off by 1.7-fold (0.23 log units), on the high side, within the range that was stated.
By their numbers in this assay, from the lowest: compounds 2, 1 and 4 (each within the scatter of the next, the first and the last beyond it); then compound 3.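

Among these compounds, compound 4 gives the first matched reading on the double-bonded nitrogen: with the rest of the structure held fixed, cyclohexyl in place of phenyl brings a 3.1-fold higher number from compound 2 to compound 4 (0.49 log units; beyond the scatter) in this assay. Both rings have the same count of heavy atoms, so in this one pair, the aromatic ring goes with stronger inhibition of growth. Nothing available explains the difference.

On these data alone, whether the same step would appear with a methyl group on the saturated ring remains open. So does how a benzyl group or a longer chain on this nitrogen would compare.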